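Series notes: ortho-methyl analogue of compound 1

The source may hold more compounds than are shown below. What is called first, only, known or untested is meant among the compounds shown, and "the series" means these compounds.

Compound 1 `O=C(Nc1cccc(-c2nc3ccccc3s2)c1)c1cc([N+](=O)[O-])ccc1Cl` stands second highest of the three numbers in an ADME assay for permeability, using PAMPA, at pH 7.4 (a lower number here means that the compound crosses the layer more slowly, a higher number that the compound crosses the layer faster), giving 12 10^-6 cm/s. Compound 2 `O=C(Nc1ccc(Cl)c(-c2nc3ccccc3s2)c1)c1cc([N+](=O)[O-])ccc1Cl` gives 3 10^-6 cm/s, and compound 3 `O=C(Nc1cc(-c2nc3ccccc3s2)ccc1F)c1cc([N+](=O)[O-])ccc1Cl` gives 191 10^-6 cm/s. Compound 4 `Cc1c(NC(=O)c2cc([N+](=O)[O-])ccc2Cl)cccc1-c1nc2ccccc2s1` differs from compound 1 by methyl in place of hydrogen on an aromatic carbon. Within the data shown here, two measured steps bear on this change, both replacing a hydrogen on an aromatic carbon with a halogen, and they pull apart: a 4.0-fold lower number from compound 1 to compound 2 (0.60 log units; beyond the scatter), whereas a 16-fold higher number from compound 1 to compound 3 (1.20 log units; beyond the scatter). Methyl is neither halogen, so the direction is uncertain; a step beyond the scatter in either direction is possible, with a mild upward lean taken from compound 3 and its 191 10^-6 cm/s. For compound 4 the expected value is 25 10^-6 cm/s, within 6 10^-6 cm/s to 100 10^-6 cm/s, which would mean a 2.1-fold higher number from compound 1 to compound 4 (0.32 log units; beyond the scatter).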

Compound 4, apparent permeability: "below limit of detection" (no number reported)
Nothing numeric was reported for compound 4, so the estimate cannot be set against anything.
By their numbers in this assay, from the lowest: compound 2; then compound 1; then compound 3.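

Among these compounds, compound 4 carries no number, so no step from compound 1 to compound 4 can be read. The compounds shown leave open how methyl in place of hydrogen on an aromatic carbon shifts the number in this assay. No measured evidence bears on this result.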